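The compounds below may be only part of what the source reports. "The series", "measured", "known", "first", "only" and "open" are said of these compounds alone.

Compound 3 `NCCCC[C@H](NC(=O)CN(c1nc(Cl)nc2[nH]cnc12)C1CC1)C(=O)OCc1ccccc1` is followed here into compound 4 `CC[C@H](C)[C@H](NC(=O)CN(c1nc(Cl)nc2[nH]cnc12)C1CC1)C(=O)OCc1ccccc1`. In a functional assay on the whole organism (Tail, strain ICR) with Mus musculus as the target, in the tail flick test, with a stated time of 60 min, at a dose of 25 umol/kg by the oral route (a lower number here means a weaker effect, a higher number a stronger effect of the compound at the dose given), compound 3 gives 41.2%, the top number of the three measured, though compound 1 `CC[C@H](C)[C@H](NC(=O)CN(c1nc(Cl)nc2[nH]cnc12)C1CC1)C(=O)O` with 36% sits within the usual scatter of it, and only compound 2 `N=C(N)NCCC[C@H](NC(=O)CN(c1nc(Cl)nc2[nH]cnc12)C1CC1)C(=O)OCc1ccccc1` with 30.6% lies clearly apart. The change is sec-butyl in place of 4-aminobutyl on a saturated chain carbon bound to an amide-type nitrogen and a carbonyl carbon. Among the measured compounds shown here, the single measured step at a side chain, a number 10.6 percentage points higher from compound 2 to compound 3 (beyond the scatter), swapped one group bearing nitrogen for another, whereas here the nitrogen leaves altogether; compound 1, which already carries sec-butyl, shows a number within the scatter of compound 3. A step of a number 3.2 percentage points lower from compound 3 to compound 4 (within the scatter) is therefore expected, within the scatter. Compound 4 is estimated at 38%, with a range from 22% to 54%.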

Compound 4, a percentage reported as activity, at one dose (the size of the read-out at that dose, not a potency): 40.6%
The estimate for compound 4 lay 2.6 percentage points below the measured number; measured number inside the range.
By their numbers in this assay, from the lowest: compounds 2, 1, 4 and 3 (each within the scatter of the next, the first and the last beyond it).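

In this assay a side chain without nitrogen serves on this chain carbon as well as those with nitrogen: sec-butyl gives (a number 0.6 percentage points lower from compound 3 to compound 4 (within the scatter)) and (a number 10 percentage points higher from compound 2 to compound 4 (within the scatter)). Benzyl on the oxygen gives (a number 4.6 percentage points higher from compound 1 to compound 4 (within the scatter)), so with sec-butyl in place, the benzyl ester and the free carboxylic acid cannot be told apart at this dose. No evidence is available to explain why these groups read alike.

Still open, from the compounds shown here alone, is how a shorter chain such as methyl, or a phenyl ring, would read on this carbon. Going by these compounds, a methyl ester in place of the benzyl ester is also open.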